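The source may report more compounds than this note shows. Statements on the series, on what has been measured and on what is new or still open speak of the compounds shown alone.

Measured so far in a physicochemical assay for solubility, at pH 7.4; a lower number here means a less soluble compound, a higher number a more soluble compound:
- compound 1 `O=C(O)COCc1nc(Nc2ccc(C(F)(F)F)cc2)c2ccc(-c3ncccc3C(F)(F)F)cc2n1`: 125 ug/mL
- compound 2 `O=C(O)CCc1nc(Nc2ccc(C(F)(F)F)cc2)c2ccc(-c3ncccc3C(F)(F)F)cc2n1`: 125 ug/mL

Going by the values given here, compound 2 stands level with its only measured neighbour, with compound 1 at 125 ug/mL and compound 2 at 125 ug/mL. The next structure is compound 3 `FC(F)(F)c1ccc(Nc2nc(CN3CCCC3)nc3cc(-c4ncccc4C(F)(F)F)ccc23)cc1`, not yet measured in this assay. The change is pyrrolidin-1-yl in place of carboxymethyl on a saturated chain carbon bound to an aromatic carbon.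

Among the compounds with values here, only one measured step bears on this, no change at the digits printed from compound 1 to compound 2 (within the scatter). It exchanged carboxymethoxy for carboxymethyl, so it shows what happens when one carboxy-bearing chain replaces another. Within the data shown here, it does not show what happens when the carboxymethyl leaves altogether, and no measured compound lacks such a chain. The step to compound 3 therefore cannot be read across from it. The starting point is compound 2 at 125 ug/mL, and a downward move is expected as a matter of judgement, with a wide margin. The estimated step is a 3.1-fold lower number from compound 2 to compound 3 (0.49 log units; beyond the scatter). For compound 3 the expected value is 40 ug/mL, with an estimated range of 8 ug/mL to 125 ug/mL.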

Compound 3, solubility: 25 ug/mL
Estimate against measurement, compound 3: 1.6-fold (0.20 log units) above, within the range that was stated.
By their numbers in this assay, from the lowest: compound 3; then compounds 1 and 2 (each within the scatter of the next).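

In this assay, the earlier pair only exchanged one carboxy-bearing chain for another, whereas the change to a group with no carboxylic acid gives a 5.0-fold lower number from compound 2 to compound 3 (0.70 log units; beyond the scatter) at this position. Set against the carboxymethoxy chain, the same replacement gives a 5.0-fold lower number from compound 1 to compound 3 (0.70 log units; beyond the scatter) with a step of the same printed size, so the result does not depend on which of the two carboxy-bearing chains is taken as the reference. The position on a saturated chain carbon bound to an aromatic carbon therefore can move this read-out, but nothing measured on these compounds accounts for the movement.

The compounds shown leave open whether the step follows the loss of the carboxylic acid or the arrival of the pyrrolidine ring, as both happen in the same change. A primary amide or a simple ether chain in the same place would separate these two readings, while a dimethylamino group, a morpholine ring or a longer chain carrying the pyrrolidine ring would show how far the result extends to other amines.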